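A Chloro for a Methyl on an Inactive Scaffold

The source may report more compounds than this note shows. Statements on the series, on what has been measured and on what is new or still open speak of the compounds shown alone.

Three compounds sharing one core have been examined in a functional assay on A549 cells (Homo sapiens) for antiproliferative activity, read by MTT assay, with a stated time of 48 h; a lower number here means a stronger inhibitor, a higher number a weaker inhibitor. Compound 1 `CN1C(=O)C2(C(C#N)=C(N)Oc3cc4oc(-c5ccccc5)cc(=O)c4c(O)c32)c2cccc(Cl)c21` reaches only the limit of the measurement, giving > 50000 nM. Compound 2 `Cc1cccc2c1N(Cc1ccccc1)C(=O)C21C(C#N)=C(N)Oc2cc3oc(-c4ccccc4)cc(=O)c3c(O)c21` likewise returns a limit, > 50000 nM. Compound 3 `N#CC1=C(N)Oc2cc3oc(-c4ccccc4)cc(=O)c3c(O)c2C12C(=O)N(Cc1ccccc1)c1ccc(Br)cc12` also sits at a limit, with > 50000 nM. Compound 2 therefore stands nowhere distinct among the numbers shown: every value is a limit rather than a measured potency, as the limit of > 50000 nM in this assay, at which 3 of the 3 values shown sit, records.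

The step to compound 4 `N#CC1=C(N)Oc2cc3oc(-c4ccccc4)cc(=O)c3c(O)c2C12C(=O)N(Cc1ccccc1)c1c(Cl)cccc12` changes one group on compound 2: chloro in place of methyl on an aromatic carbon. Within the data shown here, no measured pair in this set differs in a single place, so no step size can be read from the data. With all three values resting at the limit, nothing points to either direction in this assay, and compound 4 is expected to stay at the limit as well. The estimate for compound 4 in this assay is 50000 nM, within 20000 nM to 150000 nM. The expected step is a number no higher from compound 2 to compound 4 (the limit leaves the size open), which is no change beyond the scatter.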

Compound 4, half-maximal inhibitory concentration: > 50000 nM
Compound 4 ended at the assay's limit (the forecaster's own chance of this, stated with the estimate: 85%); the middle value lies on the limit itself.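

In this assay, among these compounds, compound 4 gives > 50000 nM, a limit, so no step to it from compound 2 or compound 1 can be read. The compounds shown leave open whether any change on the shared core would give a measurable potency, as all rest at one value: the limit of > 50000 nM in this assay, at which 4 of the 4 values shown sit.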